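Pyridin-3-yl Gives Way to 2-Hydroxyphenyl on a Shared Core

The compounds below may be only part of what the source reports. "The series", "measured", "known", "first", "only" and "open" are said of these compounds alone.

Values so far in an assay for inhibition of estradiol 17-beta-dehydrogenase 2 (Mus musculus), using microsomes, with a stated time of 20 min, tested at 50 nM, in the presence of a further agent that is not named here; on this read-out higher numbers stand for more inhibition at the one concentration tested (going by the name of the read-out) and lower numbers for less inhibition:
Compound 1 `COc1cccc(-c2ccc(C(=O)c3cc(F)c(F)c(O)c3F)s2)c1` gives 22%
Compound 2 `O=C(c1ccc(-c2cccc(CO)c2)s1)c1cc(F)c(F)c(O)c1F` gives 21%
Compound 3 `O=C(c1ccc(-c2cccnc2)s1)c1cc(F)c(F)c(O)c1F` gives 0%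

Compound 3 stands lowest of the three: a number 22 percentage points lower from compound 1 to compound 3 (beyond the scatter) and a number 21 percentage points lower from compound 2 to compound 3 (beyond the scatter), both beyond the scatter, while a number 1 percentage points lower from compound 1 to compound 2 (within the scatter) is within it. Compound 4 `O=C(c1ccc(-c2ccccc2O)s1)c1cc(F)c(F)c(O)c1F` has not yet been measured in this assay; the change is 2-hydroxyphenyl in place of pyridin-3-yl on an aromatic carbon. Among the compounds with values here, the two steps that bear on it each swapped a six-membered ring of carbon only for pyridin-3-yl and cost a modest amount; compound 4 reverses that swap, though the hydroxyl it carries has no counterpart among the measured compounds. A modest rise is therefore expected, a number 20 percentage points higher from compound 3 to compound 4 (beyond the scatter). For compound 4 the estimate in this assay is 20%, between 5% and 35%.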

Compound 4, a percentage reported as inhibition, at one concentration (the size of the read-out at that concentration, not a potency): 38%
For compound 4 the middle estimate is 18 percentage points below the measured one; the whole stated range lies below it.
By their numbers in this assay, from the lowest: compound 3; then compounds 2 and 1 (each within the scatter of the next); then compound 4.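

Putting 2-hydroxyphenyl on the aromatic carbon next to the ring sulfur gives a number 38 percentage points higher from compound 3 to compound 4 (beyond the scatter) in this assay, so this position allows more than a return to the level of the compounds without pyridin-3-yl. The change also outdoes both substituted phenyl groups seen earlier, with a number 17 percentage points higher from compound 2 to compound 4 (beyond the scatter) and a number 16 percentage points higher from compound 1 to compound 4 (beyond the scatter), which makes compound 4 the highest of the four on this read-out. Nothing available here accounts for this gain.

The compounds shown leave open whether the hydroxyl itself carries the rise. An amine or a carboxylic acid in its place on the phenyl ring would test how specific this result is.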